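Chloro for hydrogen on two cores

The compounds below may be only part of what the source reports. "The series", "measured", "known", "first", "only" and "open" are said of these compounds alone.

Measured in an assay on cells for antagonist activity at D(4) dopamine receptor (Homo sapiens), read by luminescence and beta-arrestin recruitment, with a stated time of 90 min; on this read-out higher numbers stand for weaker inhibition and lower numbers for stronger inhibition:
compound 1 `O=C(CN1CCN(c2ccccn2)CC1)Nc1cccnc1`: 25800 nM
compound 2 `Cc1cccc(NC(=O)CN2CCC(c3ccccc3)CC2)c1`: 135 nM
compound 3 `O=C(CN1CCN(c2ccc(Cl)cn2)CC1)Nc1cccnc1`: 23500 nM

Compound 2 gives the lowest number of the three, beyond the scatter from both others. How the core of compound 2 differs from that of compound 1 is not broken down here. From compound 1 to compound 3 the change is chloro in place of hydrogen on an aromatic carbon, and the step is a 1.1-fold lower number from compound 1 to compound 3 (0.04 log units; within the scatter).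

Compound 4 `Cc1cccc(NC(=O)CN2CCC(c3ccc(Cl)cc3)CC2)c1` carries the same kind of change on the core of compound 2: chloro in place of hydrogen on an aromatic carbon. Around the place the rings differ: in compound 3 the chloro sits on a six-membered aromatic ring with one nitrogen, two atoms from the ring nitrogen, whereas in compound 4 it sits on a six-membered aromatic ring of carbon only, para to a large group.

The step expected from compound 2 to compound 4 in this assay is a 1.1-fold lower number from compound 2 to compound 4 (0.05 log units; within the scatter), about as small as the earlier one, because a 1.1-fold lower number from compound 1 to compound 3 (0.04 log units; within the scatter) stayed within the scatter. Compound 4 is estimated at 120 nM, between 40 nM and 400 nM.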

Compound 4, half-maximal inhibitory concentration: 42400 nM
Compound 4: middle estimate off by 350-fold (2.55 log units), on the low side; the measured number lies above the stated range.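

In this assay, chloro in place of hydrogen on an aromatic carbon does not carry from one core to the other: the same change on two cores in this assay, a 1.1-fold lower number (0.04 log units; within the scatter) from compound 1 to compound 3 and a 310-fold higher number (2.50 log units; beyond the scatter) from compound 2 to compound 4, 340-fold (2.54 log units) apart, beyond the scatter of two such steps. The larger step is a 310-fold higher number from compound 2 to compound 4 (2.50 log units; beyond the scatter), so a step seen on one core gives no usable estimate for the other in this series. With a single pair on each core, these data show that the outcome differs between the two cores, but they do not show which structural difference between the cores accounts for this.

Open, on these data alone, is whether fluoro, methyl or methoxy in the same place on the core of compound 2 gives a similar step. Also open, as far as these compounds go, is whether chloro gives such a step on that core when a six-membered aromatic ring with one nitrogen carries it.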